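From benzoyl to butyl on compound 1

The source may report more compounds than this note shows. Statements on the series, on what has been measured and on what is new or still open speak of the compounds shown alone.

In a functional assay on HepG2 cells (Homo sapiens) for antiproliferative activity, read by MTT assay, with a stated time of 48 h (a lower number here means a stronger inhibitor, a higher number a weaker inhibitor), compound 1 (`Cc1ccccc1/C=C1\CN(C(=S)NC(=O)c2ccccc2)C/C(=C\c2ccccc2C)C1=O`) gives < 10000 nM which is a limit of the assay and not a number. Compound 2 (`Cc1ccc(/C=C2\CN(C(=S)NC(=O)c3ccccc3)C/C(=C\c3ccc(C)cc3)C2=O)cc1`) also gives only a limit, with < 10000 nM as its reading in this assay here. Compound 3 (`CCCCNC(=S)N1C/C(=C\c2ccccc2C)C(=O)/C(=C/c2ccccc2C)C1`) has butyl in place of benzoyl on an amide-type nitrogen and otherwise matches compound 1. For the measured compounds named here, no measured step shows what this swap does in this assay. The estimated step that the limit leaves unreadable from compound 1 to compound 3 is expected to be modest, with no firm direction. For compound 3 the estimate is 5000 nM and the expected range runs from 1500 nM to 15000 nM as a rough guide.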

Compound 3, half-maximal inhibitory concentration: < 10000 nM
Compound 3: a limit, no number; the forecaster's own chance of this, stated with the estimate: 30%; the middle value is on the limit's open side.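

Compound 1 and compound 3 each give only a limit of the assay and not a number in this assay, so no step can be read between them: the limit of < 10000 nM in this assay, at which 3 of the 3 values shown sit.

The compounds shown leave open how strongly each one acts, and whether butyl in place of benzoyl changes that at all.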